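This account rests on a few compounds, and the source may have more. Where it says the series, first, only, none or still open, it means among the compounds named here.

Within the data shown here, in a functional assay on PC-3 cells (Homo sapiens) for inhibition, read by MTT assay, with a stated time of 48 h (a lower number here means a stronger inhibitor, a higher number a weaker inhibitor), compound 1 `CCSc1nnc(-c2cc(OC)c(OC)c(OC)c2)n1-c1ccc(N(C)C)cc1` gives 46200 nM, the only true number in this small set. Compound 2 `COc1ccc(CSc2nnc(-c3cc(OC)c(OC)c(OC)c3)n2-c2ccc(N(C)C)cc2)cc1` is reported only as a limit, > 60000 nM. Compound 3 `COc1ccc(C(=O)CSc2nnc(-c3cc(OC)c(OC)c(OC)c3)n2-c2ccc(N(C)C)cc2)cc1O` is also reported only as a limit, > 100000 nM. Compound 3 therefore has no measured number, although its limit shows that it is a weaker inhibitor than compound 1.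

Compound 4 `COc1cc(-c2nnc(SCC(=O)Nc3ccc(Cl)cc3)n2-c2ccc(N(C)C)cc2)cc(OC)c1OC` keeps the shared core and differs from compound 3 as follows: (4-chlorophenyl)amino in place of 3-hydroxy-4-methoxyphenyl on a carbonyl carbon. Thus (4-chlorophenyl)amino stands in place of 3-hydroxy-4-methoxyphenyl on a carbonyl carbon, turning (3-hydroxy-4-methoxyphenyl)carbonyl into (4-chlorophenyl)carbamoyl.

Among the measured compounds shown here, no measured step makes this exchange. The nearest steps act on the saturated chain carbon bound to a sulfur. Putting 4-methoxyphenyl in place of methyl gave an at least 1.2-fold higher number from compound 1 to compound 2 (0.11 log units; that floor lies within the scatter). Putting (3-hydroxy-4-methoxyphenyl)carbonyl in place of methyl gave an at least 2.1-fold higher number from compound 1 to compound 3 (0.33 log units; beyond the scatter). Between these two groups there is a step that the two limits leave unreadable from compound 2 to compound 3.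

Neither readable step shows any gain in potency, so compound 4 is expected to remain a weak inhibitor, and it may well return only a limit. The expected step, small and of uncertain direction, is an at least 1.4-fold lower number from compound 3 to compound 4 (0.15 log units; that floor lies within the scatter). Compound 4 is estimated at 70000 nM, with an expected range of 25000 nM to 200000 nM.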

Compound 4, half-maximal inhibitory concentration: > 60000 nM
Compound 4: no number, only a limit; the forecaster's own chance of this, stated with the estimate: 55%; the middle value lies beyond the limit too.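

In this assay compound 4 stops at a limit, as compound 2 does: the limit of > 60000 nM in this assay, at which 2 of the 4 values shown sit. The (4-chlorophenyl)carbamoyl group on the saturated chain carbon bound to a sulfur thus joins 4-methoxyphenyl and (3-hydroxy-4-methoxyphenyl)carbonyl as a third replacement for methyl that yields no true number, and against methyl it gives an at least 1.2-fold higher number from compound 1 to compound 4 (0.11 log units; that floor lies within the scatter). The steps to compound 4 from compound 2 and from compound 3 cannot be read, so the carbamoyl and the aryl carbonyl groups cannot be ranked against each other, nor can either be ranked against 4-methoxyphenyl.

Among these compounds, how far any of these three groups weakens compound 1 stays open, as each is known only through a limit, and compound 1 is the only compound here with a true number to compare against. The compounds shown also leave open how a carboxylic acid or an amine would read in place of methyl on this saturated chain carbon.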